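The compounds below may be only part of what the source reports. "The series", "measured", "known", "first", "only" and "open" are said of these compounds alone.

Measured so far in a functional assay on CHO-K1 cells for antagonist activity at adenosine receptor A1 (Homo sapiens), read by a beta-galactosidase reporter and cAMP accumulation, with stated times of 15 min and 6 h; on this read-out lower numbers stand for stronger inhibition and higher numbers for weaker inhibition:

Compound 1 `Cc1ccc(-c2nc(N)c3cc(Cc4ccccc4)sc3n2)o1` gives 298 nM.
Compound 2 `Cc1ccc(-c2nc(N)c3cc(CCc4ccccc4)sc3n2)o1` gives 2780 nM.
Compound 3 `Cc1ccc(-c2nc(N)c3cc(C(C)c4ccccc4)sc3n2)o1` gives 439 nM.

Compound 1 has the lowest number of the three, meaning the strongest inhibition. Compound 3 sits nearest to it, the change being a 1.5-fold higher number from compound 1 to compound 3 (0.17 log units; within the scatter), so these two cannot be told apart. Compound 2 lies furthest away, with a 9.3-fold higher number from compound 1 to compound 2 (0.97 log units; beyond the scatter), a clear weakening. The step of a 6.3-fold lower number from compound 2 to compound 3 (0.80 log units; beyond the scatter) runs the other way and recovers most of that ground.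

Compound 4 `Nc1nc(-c2cccnc2)nc2sc(Cc3ccccc3)cc12` is the next compound. Its difference from compound 1 is pyridin-3-yl in place of 5-methylfuran-2-yl on an aromatic carbon. This change touches a different part of the shared core than any of the measured steps, which all alter the chain that carries the phenyl group. None of the steps seen so far therefore bears on it, and the data give no direct guide to its direction or size.

With nothing to anchor it, the estimate for compound 4 rests on compound 1 alone, and a modest weakening is expected as the more likely outcome, with a wide range to reflect the lack of a comparable step. The expected step is a 3.0-fold higher number from compound 1 to compound 4 (0.48 log units; beyond the scatter). For compound 4 in this assay the estimated value is 900 nM, with a range from 250 nM to 4000 nM.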

Compound 4, inhibition constant: 1420 nM
For compound 4 the middle estimate is 1.6-fold (0.20 log units) below the measured one; the measured number falls inside the stated range.
By their numbers in this assay, from the lowest: compounds 1 and 3 (each within the scatter of the next); then compounds 4 and 2 (each within the scatter of the next).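

Exchanging the group on the aromatic carbon between two ring nitrogen atoms changes the result in this assay, with a 4.8-fold higher number from compound 1 to compound 4 (0.68 log units; beyond the scatter). Going by these compounds alone, this shows that this position is sensitive to which aromatic ring it carries, whereas the earlier compounds varied only the chain bearing the phenyl group. The loss comes although both groups have the same number of heavy atoms and hydrogen-bond acceptors, so those counts do not separate them; they differ in having a five-membered ring with oxygen and a methyl group or a six-membered ring with nitrogen, and no measurement here explains why the change weakens inhibition.

Going by these compounds, it remains open whether ring size, the hetero atom or the methyl group accounts for the step, and a plain furan-2-yl, a thiophen-2-yl or a phenyl group at this position could help separate these. On these data alone, it is also open whether the chain effects seen among compounds 1, 2 and 3 would persist with pyridin-3-yl in place, as a phenethyl group on the core of compound 4 could show.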